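A few compounds are considered here, and "the series" means these few. Any claim that something is new, unique, unknown or untested is made for them only; others in the source may bear on it.

Values measured in a functional assay on A549 cells (Homo sapiens) for cytotoxicity; on this read-out higher numbers stand for weaker inhibition and lower numbers for stronger inhibition:
- compound 1 `C=C/C=C\[C@H](C)[C@H](OC(N)=O)[C@@H](C)[C@H](O)[C@@H](C)CC(=C)[C@H]1[C@H](C)[C@@H](O)[C@@H](C)[C@@H]1/C=C/C[C@@H]1OC(=O)[C@H](C)[C@@H](O)[C@H]1C`: 100 nM
- compound 2 `C=C/C=C\[C@H](C)[C@H](OC(N)=O)[C@@H](C)[C@H](O)[C@@H](C)C[C@@](C)(O)[C@H]1[C@H](C)[C@@H](O)[C@@H](C)[C@@H]1/C=C/C[C@@H]1OC(=O)[C@H](C)[C@@H](O)[C@H]1C`: 840 nM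
- compound 3 `C=C/C=C\[C@H](C)[C@H](OC(N)=O)[C@@H](C)[C@H](O)[C@@H](C)C[C@](C)(O)[C@H]1[C@H](C)[C@@H](O)[C@@H](C)[C@@H]1/C=C/C[C@@H]1OC(=O)[C@H](C)[C@@H](O)[C@H]1C`: 2640 nM

Compound 3 has the highest number of the three and so is the weakest inhibitor in the set. Its value lies clearly above those of compound 2 and compound 1. The next analogue, compound 4 `C=C/C=C\[C@H](C)[C@H](OC(N)=O)[C@@H](C)[C@H](O)[C@H](C)C[C@](C)(O)[C@H]1[C@H](C)[C@@H](O)[C@@H](C)[C@@H]1/C=C/C[C@@H]1OC(=O)[C@H](C)[C@@H](O)[C@H]1C`, keeps every atom and bond of compound 3: the two compounds have the same atoms and bonds and differ only in configuration as drawn: 1 of 17 stereo elements differ; a stereocentre at a saturated chain carbon is drawn S in compound 3 and R in compound 4. For the measured compounds named here, only one measured step bears on this kind of change, a 3.1-fold higher number from compound 2 to compound 3 (0.50 log units; beyond the scatter), and it can be put down to the fact that compounds 2 and 3 differ only in the configuration as drawn. It shows that inverting a single centre can shift this series by a modest amount. A step of similar size is therefore expected in this assay. The direction is not established, though a higher number seems somewhat more likely than a lower one. The expected change is a 1.5-fold higher number from compound 3 to compound 4 (0.18 log units; within the scatter). The estimate for compound 4 is 4000 nM, with an expected range from 1100 nM to 14000 nM.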

Compound 4, half-maximal inhibitory concentration: > 5000 nM
Compound 4: only a limit was reported (the forecaster's own chance of this, stated with the estimate: 12%); middle value at least 1.2-fold (0.09 log units) from the limit.
By their numbers in this assay, from the lowest: compound 1; then compound 2; then compound 3. At a limit, above all of these: compound 4.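

In this assay compound 4 carries only a limit, > 5000 nM, not a number. The new inversion, at a second stereocentre on a saturated chain carbon, gives an at least 1.8-fold higher number from compound 3 to compound 4 (0.27 log units; that floor lies within the scatter); the floor of this step does not separate the two compounds, but no gain in inhibition appears, a point the earlier compounds could not show for this centre: the fact that compounds 3 and 4 differ only in the configuration as drawn Two inverted stereocentres taken together give an at least 5.9-fold higher number from compound 2 to compound 4 (0.77 log units; beyond the scatter), so configuration alone at these chain carbons moves the number clearly beyond the scatter: the fact that compounds 2 and 4 differ only in the configuration as drawn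

From the compounds shown here alone, the true size of the step at this centre stays open, since the limit hides how weak compound 4 is. Also open, going by these compounds, is what an ethyl group or a fluorine atom would do in place of the methyl group on this stereocentre.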